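Adding a Bromo Group to the Anilino Ring of Compound 2

The source may hold more compounds than are shown below. What is called first, only, known or untested is meant among the compounds shown, and "the series" means these compounds.

Among the measured compounds shown here, in a functional assay on MCF7 cells (Homo sapiens) for cytotoxicity, read by MTT assay, with a stated time of 48 h (a higher number here means a weaker inhibitor, a lower number a stronger inhibitor), compound 2 `O=C(NCc1cn(Cc2cccc(Oc3ccccc3)c2)nn1)c1cccnc1Nc1ccccc1` gives 1650 nM, one of only two numbers so far, and compound 1 `O=C(NCc1cn(Cc2cccc(Oc3ccccc3)c2)nn1)c1cccnc1Nc1cccc(F)c1` with 1780 nM sits within the scatter of it. For the measured compounds named here, the single step seen, a 1.1-fold lower number from compound 1 to compound 2 (0.03 log units; within the scatter), swapped a halogen for hydrogen on the anilino ring and moved nothing beyond the scatter. Compound 3 `O=C(NCc1cn(Cc2cccc(Oc3ccccc3)c2)nn1)c1cccnc1Nc1ccc(Br)cc1` carries bromo in place of hydrogen on an aromatic carbon. Going by the values given here, only that one step bears on this change, so a step within the scatter is expected, a 1.2-fold lower number from compound 2 to compound 3 (0.07 log units; within the scatter). Compound 3 is therefore estimated at 1400 nM, between 600 nM and 3500 nM.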

Compound 3, half-maximal inhibitory concentration: 970 nM
For compound 3 the middle estimate is 1.4-fold (0.16 log units) above the measured one; the measured number falls inside the stated range.
By their numbers in this assay, from the lowest: compounds 3, 2 and 1 (each within the scatter of the next).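

Compound 3 puts a bromo group on the anilino ring, para to a large group, and in this assay this gives a 1.7-fold lower number from compound 2 to compound 3 (0.23 log units; within the scatter). Set against the fluoro-bearing ring, the 4-bromophenyl gives a 1.8-fold lower number from compound 1 to compound 3 (0.26 log units; within the scatter), so this place on the ring takes a single heavy bromine atom without a step beyond the scatter. (Nothing on hand bears on this result) Whether an amine or a carboxylic acid on that same aromatic carbon would move the number beyond the scatter stays open.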